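Notes on the 2,6-dichlorophenyl step from compound 2

This account rests on a few compounds, and the source may have more. Where it says the series, first, only, none or still open, it means among the compounds named here.

compound 1 `CC(C)[C@H](NC(=O)COc1cccc2ccccc12)C(=O)N[C@@H](CC(=O)O)C(=O)COc1ccccc1` gives 11200 nM
compound 2 `CC(C)[C@H](NC(=O)COc1cccc2ccccc12)C(=O)N[C@@H](CC(=O)O)C(=O)COc1cc(F)c(F)cc1F` gives 16700 nM

In a functional assay with Homo sapiens as the target (on this read-out higher numbers stand for weaker inhibition and lower numbers for stronger inhibition), compound 2 at 16700 nM stands level with compound 1 within the scatter. Next is compound 3 `CC(C)[C@H](NC(=O)COc1cccc2ccccc12)C(=O)N[C@@H](CC(=O)O)C(=O)COc1c(Cl)cccc1Cl` for which no value exists yet. The change 2,6-dichlorophenyl in place of 2,4,5-trifluorophenyl on an oxygen on a saturated carbon puts 2,6-dichlorophenyl in place of 2,4,5-trifluorophenyl on an oxygen on a saturated carbon. Among the compounds with values here, the only measured step at this place a 1.5-fold higher number from compound 1 to compound 2 (0.17 log units; within the scatter) stays within the scatter and is a single case. The step expected in this assay is a 1.3-fold lower number from compound 2 to compound 3 (0.11 log units; within the scatter) and thus none beyond the scatter. Compound 3 is estimated at 13000 nM with an expected range of 5000 nM to 30000 nM for the coming measurement.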

Compound 3, half-maximal inhibitory concentration: 15300 nM
For compound 3 the middle estimate is 1.2-fold (0.07 log units) below the measured one; the measured number falls inside the stated range.
By their numbers in this assay, from the lowest: compounds 1, 3 and 2 (each within the scatter of the next).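

Against the phenyl of compound 1, the step in this assay is a 1.4-fold higher number from compound 1 to compound 3 (0.14 log units; within the scatter), and exchanging the fluorines for chlorines gives a 1.1-fold lower number from compound 2 to compound 3 (0.04 log units; within the scatter) here. Phenyl, 2,4,5-trifluorophenyl and 2,6-dichlorophenyl on an oxygen on a saturated carbon therefore all stand level, so this position now shows chlorine as well as fluorine substitution with no step beyond the scatter. No evidence is available that bears on this result.

On these data alone, whether any group at this place gives a step beyond the scatter stays open. An amine or a longer chain in place of the aryl group would address that.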